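Bromo for methoxy: from compound 3 to compound 4

This account rests on a few compounds, and the source may have more. Where it says the series, first, only, none or still open, it means among the compounds named here.

In a functional assay on SK-OV-3 cells (Homo sapiens) for cytotoxicity (on this read-out higher numbers stand for weaker inhibition of growth and lower numbers for stronger inhibition of growth), compound 3 (`COc1ccc(C2=C(c3ccc(SC)cc3)CC3CCCN3C2=O)cc1`) gives 3000 nM and compound 2 (`CSc1ccc(C2=C(c3ccc(F)c(F)c3)C(=O)N3CCCC3C2)cc1`) gives 100 nM, which leaves compound 3 with the higher of the two actual numbers. Compound 1 (`COc1ccc(C2=C(c3ccc(SC)cc3)CC3CCCN3C2=O)cc1O`) reads > 100000 nM, which is a limit of the assay and not a number.

Compound 4 (`CSc1ccc(C2=C(c3ccc(Br)cc3)C(=O)N3CCCC3C2)cc1`) is not yet measured. It differs from compound 3 by bromo in place of methoxy on an aromatic carbon, para to a large group: bromo in place of methoxy on an aromatic carbon.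

The closest measured change at this phenyl is a 30-fold higher number from compound 2 to compound 3 (1.48 log units; beyond the scatter), with 4-methoxyphenyl taking the place of 3,4-difluorophenyl. Read in reverse, that step shows a large gain on leaving the methoxy-bearing phenyl. Two further steps at the same phenyl are also large: an at least 1000-fold lower number from compound 1 to compound 2 (3.00 log units; beyond the scatter) and an at least 33-fold lower number from compound 1 to compound 3 (1.52 log units; beyond the scatter). Both rest on the limit of compound 1 and give only a bound on size: the limit of > 100000 nM in this assay, at which 1 of the 3 values shown sits.

Bromo itself has not been tested here, and compound 2 is the only halogen-bearing example, so its gap carries over only in part. A large step to a lower number is therefore expected, somewhat smaller than that seen for compound 2 at a 30-fold higher number from compound 2 to compound 3 (1.48 log units; beyond the scatter). The expected step is a 15-fold lower number from compound 3 to compound 4 (1.18 log units; beyond the scatter). The estimate for compound 4 is 200 nM, with an expected range from 40 nM to 1500 nM.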

Compound 4, concentration for 50% growth inhibition: 9000 nM
Compound 4: the middle estimate sits 45-fold (1.65 log units) below what was measured, outside the stated range (above it).
By their numbers in this assay, from the lowest: compound 2; then compound 3; then compound 4. At a limit, above all of these: compound 1.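

In this assay, a 3.0-fold higher number from compound 3 to compound 4 (0.48 log units; beyond the scatter), so exchanging methoxy for bromo on this aromatic carbon does not bring the series towards the low number of compound 2. Within the data shown here, the two halogen-bearing phenyls also lie far apart, with a 90-fold higher number from compound 2 to compound 4 (1.95 log units; beyond the scatter): a halogen on this phenyl does not by itself go with a low number, and compound 4 stands against that reading, which compound 2 alone had left possible, so the low number so far belongs to the 3,4-difluorophenyl of compound 2 and not to halogen as such. Compound 4 remains on the lower side of compound 1, but an at least 11-fold lower number from compound 1 to compound 4 (1.04 log units; beyond the scatter) rests on the limit of compound 1 and gives only a bound: the limit of > 100000 nM in this assay, at which 1 of the 4 values shown sits.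

Going by these compounds, whether a single fluoro or a chloro in place of bromo on this aromatic carbon would read nearer compound 2 or nearer compound 4 stays open. Also open is how this assay responds to a nitrile, an amine or a carboxylic acid at this carbon, since the compounds shown cover only hydroxy, methoxy and halogen on this phenyl.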